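Chain Branching on the Aromatic Nitrogen of the Shared Core

A few compounds are considered here, and "the series" means these few. Any claim that something is new, unique, unknown or untested is made for them only; others in the source may bear on it.

Compound 1 `CCCn1cnc2ncnc(N)c21` carries a propyl on the aromatic nitrogen of the shared core. In an assay on CHO cells for displacement of a labelled ligand from adenosine receptor A3 (Homo sapiens) (a higher number here means a weaker inhibitor, a lower number a stronger inhibitor), compound 1 gives only a limit of the assay, > 100000 nM. Compound 2 `CC(C)n1cnc2ncnc(N)c21` carries isopropyl in its place. In this assay compound 2 likewise reaches only a limit, > 100000 nM. The step that the two limits leave unreadable from compound 1 to compound 2 is therefore not readable; both values sit at the limit of > 100000 nM in this assay, at which 2 of the 2 values shown sit, so compound 2 stands at the weak end of everything shown, without a number. Compound 3 `CCC(C)n1cnc2ncnc(N)c21` differs from compound 2 by methyl in place of hydrogen on a saturated chain carbon, two bonds along the chain from an aromatic nitrogen. Among the measured compounds shown here, the only measured step in this assay is unreadable, so no size or direction can be drawn from it. Compound 3 is therefore expected to remain at or beyond the same limit, the step that the limit leaves unreadable from compound 2 to compound 3 being an expectation and not a reading. Compound 3 is estimated at 150000 nM, within 50000 nM to 500000 nM.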

Compound 3, inhibition constant: > 100000 nM
Compound 3 ended at the assay's limit; the forecaster's own chance of this, stated with the estimate: 85%; the middle value lies beyond the limit too.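

No new step can be read: compound 1, compound 2 and compound 3 all stay at a limit of the assay, and the steps among them remain unreadable: the limit of > 100000 nM in this assay, at which 3 of the 3 values shown sit.

The compounds shown leave open which group on the aromatic nitrogen of the shared core, if any, would give a measurable value in this assay.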